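This account rests on a few compounds, and the source may have more. Where it says the series, first, only, none or still open, it means among the compounds named here.

Two compounds share one core and differ only in the side chain of the amide. Compound 1 `COc1cc2ncnc(N3CCCc4ccccc43)c2cc1NC(=O)/C=C/C(C)C` and compound 2 `CCN(CC)C/C=C/C(=O)Nc1cc2c(N3CCCc4ccccc43)ncnc2cc1OC` were both tested in a functional assay on PC-3 cells (Homo sapiens) for antiproliferative activity, read by MTT assay, with a stated time of 72 h; on this read-out higher numbers stand for weaker inhibition and lower numbers for stronger inhibition. Compound 1 gives 8430 nM, and compound 2 gives 6890 nM, the step of a 1.2-fold lower number from compound 1 to compound 2 (0.09 log units; within the scatter). Compound 3 `COc1cc2ncnc(N3CCCc4ccccc43)c2cc1NC(=O)/C=C/CN1CCCC1` carries a further change: pyrrolidin-1-yl in place of diethylamino on a saturated chain carbon bound to a double-bonded chain carbon. Among the compounds with values here, no measured step exchanges one amine for another; the only step at hand stayed within the scatter, so no change beyond the scatter is expected, and the expected step is a 1.1-fold lower number from compound 2 to compound 3 (0.03 log units; within the scatter). Compound 3 is therefore estimated at 6500 nM, between 3000 nM and 14000 nM.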

Compound 3, half-maximal inhibitory concentration: 1740 nM
Estimate against measurement, compound 3: 3.7-fold (0.57 log units) above; the measured number lies below the stated range.
By their numbers in this assay, from the lowest: compound 3; then compounds 2 and 1 (each within the scatter of the next).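

In this assay, the amine on this saturated chain carbon matters: tying diethylamino into the ring of pyrrolidin-1-yl, with the same count of heavy atoms, gives a 4.0-fold lower number from compound 2 to compound 3 (0.60 log units; beyond the scatter). Set against isopropyl, (pyrrolidin-1-yl)methyl gives a 4.8-fold lower number from compound 1 to compound 3 (0.69 log units; beyond the scatter), whereas (diethylamino)methyl had stayed within the scatter in that place. Nothing measured here gives a reason for this. From the compounds shown here alone, whether a six-membered ring such as piperidin-1-yl or morpholin-4-yl, or a smaller open amine such as dimethylamino, would follow pyrrolidin-1-yl or diethylamino remains open.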